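Swapping the trichlorophenyl for a fluorophenyl on compound 2

The source may hold more compounds than are shown below. What is called first, only, known or untested is meant among the compounds shown, and "the series" means these compounds.

Compound 2 `CCCN1CCN(c2ccc(S(=O)(=O)Oc3cc(Cl)c(Cl)cc3Cl)cc2)C1=O` gives 19000 nM in a functional assay on HT-29 cells (Homo sapiens) for antiproliferative activity, read by sulforhodamine B assay, with a stated time of 48 h (a lower number here means a stronger inhibitor, a higher number a weaker inhibitor), the highest number of the three measured compounds, though compound 3 `CCCN1CCN(c2ccc(S(=O)(=O)Oc3ccc(OC)c(OC)c3)cc2)C1=O` at 14000 nM sits within the scatter of it. Compound 1 `CN1CCN(c2ccc(S(=O)(=O)Oc3cc(Cl)c(Cl)cc3Cl)cc2)C1=O` gives 600 nM, and the step of a 32-fold higher number from compound 1 to compound 2 (1.50 log units; beyond the scatter) is the only one beyond the scatter. Compound 4 `CCCN1CCN(c2ccc(S(=O)(=O)Oc3ccc(F)cc3)cc2)C1=O` differs from compound 2 in that (4-fluorophenyl in place of 2,4,5-trichlorophenyl on an oxygen). For the measured compounds named here, no measured step changes this part of the structure; the only guide is that compound 2 and compound 3, which carry different aryl groups on that oxygen, sit within the scatter of each other. Compound 4 is therefore expected near compound 2, with the expected step of a 1.1-fold higher number from compound 2 to compound 4 (0.02 log units; within the scatter), giving an estimate of 20000 nM in a range of 6000 nM to 60000 nM.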

Compound 4, half-maximal inhibitory concentration: 23000 nM
Compound 4: the middle estimate sits 1.2-fold (0.06 log units) below what was measured; measured number inside the range.
By their numbers in this assay, from the lowest: compound 1; then compounds 3, 2 and 4 (each within the scatter of the next).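

For the compounds shown here, putting 4-fluorophenyl in place of 2,4,5-trichlorophenyl on the oxygen bound to the sulfonyl sulfur gives a 1.2-fold higher number from compound 2 to compound 4 (0.08 log units; within the scatter) in this assay and so this is the first direct step at this position, and it cannot be told from the scatter. On the core of compound 2, then, this swap leaves the reading unchanged, and no measurement here offers an explanation for that.

The same swap could still read differently on the core of compound 1, which gives 600 nM in this assay. On these data alone, it is also open whether an aryl ring carrying an amine or a carboxylic acid on that oxygen would behave like these aryl groups.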